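Swapping 4-methylphenyl for cyclopropyl at an assay limit

This account rests on a few compounds, and the source may have more. Where it says the series, first, only, none or still open, it means among the compounds named here.

Measured in a functional assay on KYSE-70 cells for antiproliferative activity against KYSE-70 cell line (Homo sapiens), read by MTT assay, with a stated time of 72 h; a lower number here means a stronger inhibitor, a higher number a weaker inhibitor:
Compound 1 `O=C(Nc1cccc(F)c1)c1cc(=O)[nH]c2cc(-c3ccccc3)ccc12`: > 20000 nM, a limit
Compound 2 `Cc1ccc(-c2ccc3c(C(=O)Nc4cccc(F)c4)cc(=O)[nH]c3c2)cc1`: > 20000 nM, a limit

Compound 2 has no numerical value on this evidence. In this assay compound 2 gives > 20000 nM, which is a limit and not a number. The same holds across the small set, which shows (the limit of > 20000 nM in this assay, at which 2 of the 2 values shown sit).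

The next compound is compound 3 `O=C(Nc1cccc(F)c1)c1cc(=O)[nH]c2cc(C3CC3)ccc12`, which keeps the core of compound 2 and changes one group: cyclopropyl in place of 4-methylphenyl on an aromatic carbon. The change replaces the 4-methylphenyl with a cyclopropyl on the same aromatic carbon.

Among the compounds with values here, only one measured step bears on this. It is a step that the two limits leave unreadable from compound 1 to compound 2, so it offers no size to carry over, and it concerns a methyl rather than the loss of the whole aryl group. Within the data shown here, no step of known size can therefore be projected, and the data give no direction for one. The most likely outcome is that this assay again reports a limit for compound 3.

The estimated step is a step that the limit leaves unreadable from compound 2 to compound 3. Compound 3 is expected near 25000 nM, with an estimated range from 8000 nM to 60000 nM.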

Compound 3, half-maximal inhibitory concentration: > 20000 nM
Compound 3: a limit, no number; the forecaster's own chance of this, stated with the estimate: 75%; the middle value is on the limit's open side.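

In this assay compound 3 gives > 20000 nM, a limit and not a number. The steps from compound 1 and compound 2 to compound 3 cannot be read, and the set shows only this: the limit of > 20000 nM in this assay, at which 3 of the 3 values shown sit.

The compounds shown leave open whether changing the group on this aromatic carbon alters activity at all.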